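What a pyrrolidin-1-yl swap may do to compound 1

The source may hold more compounds than are shown below. What is called first, only, known or untested is meant among the compounds shown, and "the series" means these compounds.

Compound 1 `CNC(=O)/C=C/CN1CC(Oc2ccc(Oc3c(-c4ccc(F)cc4)sc4cc(O)ccc34)cc2)C1` has no exact number in a functional assay on Ishikawa cells (Homo sapiens) for antiproliferative activity, read by CCK-8 assay, with a stated time of 48 h; on this read-out higher numbers stand for weaker inhibition and lower numbers for stronger inhibition: compound 1 gives > 25000 nM, which is a limit. Compound 2 `C=CC(=O)NCCOc1ccc(Oc2c(-c3ccc(F)cc3)sc3cc(O)ccc23)cc1` also ends at a limit, > 25000 nM. Compound 3 `CNC(=O)/C=C/CNCCOc1ccc(Oc2c(-c3ccc(F)cc3)sc3cc(O)ccc23)cc1` gives a true number, 15500 nM. Together these show (the limit of > 25000 nM in this assay, at which 2 of the 3 values shown sit). Compound 4 `O=C(/C=C/CN1CC(Oc2ccc(Oc3c(-c4ccc(F)cc4)sc4cc(O)ccc34)cc2)C1)N1CCCC1` carries pyrrolidin-1-yl in place of methylamino on a carbonyl carbon. Within the data shown here, none of the measured steps makes this swap. They are a step that the two limits leave unreadable from compound 1 to compound 2, an at least 1.6-fold lower number from compound 1 to compound 3 (0.20 log units; that floor lies within the scatter) and an at least 1.6-fold lower number from compound 2 to compound 3 (0.20 log units; that floor lies within the scatter), and none is readable as a step beyond the scatter. So no step beyond the scatter is expected in this assay. The estimated step is a step that the limit leaves unreadable from compound 1 to compound 4. Compound 4 is expected at 28000 nM, with an estimated range of 14000 nM to 60000 nM.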

Compound 4, half-maximal inhibitory concentration: 9150 nM
For compound 4 the middle estimate is 3.1-fold (0.49 log units) above the measured one; measured number outside the range, below it.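

Pyrrolidin-1-yl in place of methylamino on a carbonyl carbon gives an at least 2.7-fold lower number from compound 1 to compound 4 (0.43 log units; beyond the scatter) in this assay, the first step here readable beyond the scatter. The swap removes the amide hydrogen and adds a five-membered ring, and this single pair cannot separate those two changes. The step is only a floor, since its starting point is a limit: the limit of > 25000 nM in this assay, at which 2 of the 4 values shown sit.

On these data alone, whether dimethylamino, with no amide hydrogen and no ring, or piperidin-1-yl would act like pyrrolidin-1-yl remains open. So does whether pyrrolidin-1-yl would give a similar step on the open chain of compound 3.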